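Furan-3-yl for phenyl on a shared core that has shown no activity

The source may hold more compounds than are shown below. What is called first, only, known or untested is meant among the compounds shown, and "the series" means these compounds.

The shared core of compound 1 `COc1ncnc2c1c(-c1ccccc1)cn2[C@@H]1O[C@H](CO)[C@@H](O)[C@H]1O`, compound 2 `CNc1ncnc2c1c(-c1ccccc1)cn2[C@@H]1O[C@H](CO)[C@@H](O)[C@H]1O` and compound 3 `CSc1ncnc2c1c(-c1ccccc1)cn2[C@@H]1O[C@H](CO)[C@@H](O)[C@H]1O` differs among the three only in the group on one aromatic carbon. In a functional assay on HepG2 cells (Homo sapiens) for antiproliferative activity, read by XTT assay, with a stated time of 72 h (a lower number here means a stronger inhibitor, a higher number a weaker inhibitor), compound 1 gives > 20000 nM, which is a limit of the assay and not a number. In this assay compound 2 likewise gives > 20000 nM, also a limit. Compound 3 gives > 20000 nM, again a limit. Compound 3 therefore stands at the limit of > 20000 nM in this assay, at which 3 of the 3 values shown sit, with nothing to separate it from the other two. The three steps, a step that the two limits leave unreadable from compound 1 to compound 2, a step that the two limits leave unreadable from compound 1 to compound 3 and a step that the two limits leave unreadable from compound 2 to compound 3, are all unreadable for the same reason.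

Compound 4 `CSc1ncnc2c1c(-c1ccoc1)cn2[C@@H]1O[C@H](CO)[C@@H](O)[C@H]1O` is made from compound 3 by the change (furan-3-yl in place of phenyl on an aromatic carbon). Within the data shown here, none of the measured steps touches the group that is exchanged here; all three concern the group on the other aromatic carbon and all end at a limit. Nothing measured supports a move in either direction, so the step from compound 3 to compound 4 is expected to be a number no higher from compound 3 to compound 4 (the limit leaves the size open), with a limit again the most likely outcome. Compound 4 is estimated at 20000 nM in this assay, in a range from 5000 nM to 100000 nM.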

Compound 4, half-maximal inhibitory concentration: > 15000 nM
Compound 4: no number, only a limit; the forecaster's own chance of this, stated with the estimate: 75%; the middle value lies beyond the limit too.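

In this assay, among these compounds, compound 4 gives > 15000 nM, which is a limit of the assay and not a number, and compound 3 also stands at a limit, so no step between compound 3 and compound 4 can be read. The compounds shown leave open whether furan-3-yl in place of phenyl changes the activity at all, and whether any group on this shared core gives a measurable value.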